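The compounds below may be only part of what the source reports. "The series", "measured", "known", "first", "only" and "open" are said of these compounds alone.

Compound 2, `CC(=O)O[C@@H]1[C@@H](OC(C)=O)[C@H](OC(C)=O)CO[C@H]1CC(=O)/C=C/c1cccc(NS(=O)(=O)c2ccc(C)cc2)c1`, was examined in an ADME assay on Vero cells (Chlorocebus sabaeus) for cytotoxicity, read by resazurin assay, with a stated time of 2 days (on this read-out lower numbers stand for higher toxicity in this test and higher numbers for lower toxicity in this test), where compound 2 gives 268000 nM. Among the two numbers known so far this is the lowest; its only companion is compound 1, `CC(=O)OC[C@H]1O[C@@H](CC(=O)/C=C/c2cccc(NS(=O)(=O)c3ccc(C)cc3)c2)[C@H](OC(C)=O)[C@@H](OC(C)=O)[C@@H]1OC(C)=O`, which in this assay gives 584000 nM, and the step of a 2.2-fold lower number from compound 1 to compound 2 (0.34 log units; beyond the scatter) shows how the two stand apart. Compound 3, `CC(=O)O[C@@H]1[C@@H](OC(C)=O)[C@H](OC(C)=O)CO[C@H]1CC(=O)/C=C/c1cccc(NC(=O)Nc2ccccc2)c1`, follows from compound 2 by a change at the anilide position: phenylcarbamoyl in place of (4-methylphenyl)sulfonyl on a nitrogen on an aromatic ring. Within the data shown here, the one measured step, hydrogen in place of acetoxymethyl on a saturated ring carbon, concerns a different part of the molecule, so no measured step bears on the exchange of the sulfonyl for the urea, and the enone, the acetylated pyranose and the aryl ring are kept. In the absence of a relevant precedent the step of no change at the digits printed from compound 2 to compound 3 (within the scatter) is expected to be none beyond the scatter, though the range must be wide. Compound 3 is therefore estimated to give 268000 nM in this assay, with a plausible range from 100000 nM to 700000 nM.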

Compound 3, half-maximal cytotoxic concentration: 102000 nM
The estimate for compound 3 lay 2.6-fold (0.42 log units) above the measured number; measured number inside the range.
By their numbers in this assay, from the lowest: compound 3; then compound 2; then compound 1.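

The exchange at the nitrogen on an aromatic ring shows that this site also affects the read-out in this assay: a 2.6-fold lower number from compound 2 to compound 3 (0.42 log units; beyond the scatter). The earlier step, a 2.2-fold lower number from compound 1 to compound 2 (0.34 log units; beyond the scatter), involved a change elsewhere in the molecule. On this read-out, the lower number for compound 3 stands for higher toxicity in this test than compound 2 shows, with phenylcarbamoyl, which has 1 hydrogen-bond donor and 1 hydrogen-bond acceptor, replacing (4-methylphenyl)sulfonyl, which has 0 donors and 2 acceptors. Nothing available accounts for this shift or links it to any one of the differences between the two groups.

The pair leaves open whether the shift follows the replacement of the sulfonyl by the carbonyl link, the added nitrogen, or the absence of the methyl group on the outer aromatic ring. It also leaves open how a free amine, an acetyl group or a methanesulfonyl group on the same nitrogen would read, and whether phenylcarbamoyl would produce a similar step on the core of compound 1, which carries acetoxymethyl.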